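Aryl ketone variation on the shared core

The source may hold more compounds than are shown below. What is called first, only, known or untested is meant among the compounds shown, and "the series" means these compounds.

Three analogues share one core and differ only in the group on the carbonyl carbon. Compound 1 `CN(C)C(=S)SCC(CSC(=S)N(C)C)C(=O)c1ccccc1F` gives 920 nM in a functional assay on NCI-H460 cells (Homo sapiens) for inhibition, read by MTT assay, with a stated time of 72 h; a lower number here means a stronger inhibitor, a higher number a weaker inhibitor; compound 2 `COc1ccccc1C(=O)C(CSC(=S)N(C)C)CSC(=S)N(C)C` gives 810 nM; compound 3 `CN(C)C(=S)SCC(CSC(=S)N(C)C)C(=O)c1nccs1` gives 840 nM. Compound 3 sits in the middle of the three numbers, yet all three lie within the scatter of one another, as a 1.1-fold lower number from compound 1 to compound 3 (0.04 log units; within the scatter) and a 1.0-fold higher number from compound 2 to compound 3 (0.02 log units; within the scatter) show. Compound 4 `CN(C)C(=S)SCC(CSC(=S)N(C)C)C(=O)c1ccc[nH]1` carries 1H-pyrrol-2-yl in place of 1,3-thiazol-2-yl on a carbonyl carbon. The measured steps of a 1.1-fold lower number from compound 1 to compound 2 (0.06 log units; within the scatter), a 1.1-fold lower number from compound 1 to compound 3 (0.04 log units; within the scatter) and a 1.0-fold higher number from compound 2 to compound 3 (0.02 log units; within the scatter) each exchanged the group on the carbonyl carbon without moving the number beyond the scatter, so no step beyond the scatter is expected for compound 4 in this assay. Compound 4 is therefore estimated at 850 nM, range 450 nM to 1600 nM. The expected step is a 1.0-fold higher number from compound 3 to compound 4 (0.01 log units; within the scatter).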

Compound 4, half-maximal inhibitory concentration: 97300 nM
Compound 4: the middle estimate sits 110-fold (2.06 log units) below what was measured, and the stated range ends below it.
By their numbers in this assay, from the lowest: compounds 2, 3 and 1 (each within the scatter of the next); then compound 4.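

The group on the carbonyl carbon is not freely exchangeable in this assay: 1H-pyrrol-2-yl gives a 120-fold higher number from compound 3 to compound 4 (2.06 log units; beyond the scatter) and a 120-fold higher number from compound 2 to compound 4 (2.08 log units; beyond the scatter) and also a 110-fold higher number from compound 1 to compound 4 (2.02 log units; beyond the scatter) on the shared core. The tolerance seen among 2-fluorophenyl, 2-methoxyphenyl and 1,3-thiazol-2-yl therefore does not extend to every aromatic group here. Unlike 1,3-thiazol-2-yl, 1H-pyrrol-2-yl carries a hydrogen-bond donor, but no measurement available here explains the step.

Going by these compounds, whether that ring hydrogen matters remains open. A 1-methyl-1H-pyrrol-2-yl or furan-2-yl group on the carbonyl carbon would test this.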